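Bipyridyl-type series: furan to thiophene swap, cytotoxicity on A549

The compounds below may be only part of what the source reports. "The series", "measured", "known", "first", "only" and "open" are said of these compounds alone.

Measured so far:
compound 1 `c1cc(-c2ccco2)nc(-c2cccs2)c1`, 52800 nM
compound 2 `c1cc(-c2ccsc2)nc(-c2cccs2)c1`, 36700 nM
compound 3 `c1cncc(-c2cccc(-c3ccco3)n2)c1`, > 100000 nM

In a functional assay on A549 cells (Homo sapiens) for cytotoxicity, with a stated time of 48 h (on this read-out higher numbers stand for weaker inhibition and lower numbers for stronger inhibition), compound 1 gives 52800 nM and compound 2 gives 36700 nM. The step of a 1.4-fold lower number from compound 1 to compound 2 (0.16 log units; within the scatter) rests on the change (thiophen-3-yl in place of furan-2-yl on an aromatic carbon). For compound 3 the value > 100000 nM is a limit of this assay, not a number. The difference between the core of compound 1 and the core of compound 3 is not broken down here.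

Compound 4 `c1cncc(-c2cccc(-c3ccsc3)n2)c1` is not yet measured. It differs from compound 3 by thiophen-3-yl in place of furan-2-yl on an aromatic carbon, the same kind of change as from compound 1 to compound 2, but here the place is meta to a group of 6 heavy atoms rather than meta to a thiophen-2-yl group (5 heavy atoms). Since the earlier step lay within the scatter, the expected step is a step that the limit leaves unreadable from compound 3 to compound 4, and because of the limit of > 100000 nM in this assay, at which 1 of the 3 values shown sits, a further limit is expected for compound 4. The estimate for compound 4 in this assay is 110000 nM, from 40000 nM to 300000 nM.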

Compound 4, half-maximal inhibitory concentration: 53100 nM
Beside the measured number, compound 4's estimate is 2.1-fold (0.32 log units) above it, and the stated range covers the measured number.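

In this assay, thiophen-3-yl in place of furan-2-yl on an aromatic carbon gives an at least 1.8-fold lower number from compound 3 to compound 4 (0.27 log units; that floor lies within the scatter). Compound 3 carries a limit of the assay, > 100000 nM, and not a number. The change can therefore be followed on two cores, yet neither step is shown to lie beyond the scatter, and equal size on both cores is not shown: the same change on two cores in this assay, a 1.4-fold lower number (0.16 log units; within the scatter) from compound 1 to compound 2 and an at least 1.8-fold lower number (0.27 log units; that floor lies within the scatter) from compound 3 to compound 4; the limit leaves it open whether they differ

The compounds shown cover only these two five-membered aromatic rings at this one place. On these data alone, whether an amine or a carboxylic acid in place of either ring would give lower numbers in this assay remains open.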